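Shortening an alkyl chain on a chlorophenyl biguanide-type scaffold

The compounds below may be only part of what the source reports. "The series", "measured", "known", "first", "only" and "open" are said of these compounds alone.

The series comprises four compounds built on closely related cores. Compound 1 `CCCCCCCCCCCCNC(=N)NC(=N)Nc1ccc(Cl)cc1` carries a long chain and, in a physicochemical assay for lipophilicity, in phosphate buffer, measured as octanol-water partition, at pH 11.5 (on this read-out lower numbers stand for lower lipophilicity and higher numbers for higher lipophilicity), compound 1 gives 7.13. Compound 2 `CCCCCCCCNC(=N)NC(=N)Nc1ccc(Cl)cc1` differs from it by the change (hydrogen in place of butyl on a saturated chain carbon, eight bonds along the chain from an amine nitrogen), and the result is a number 2.00 log units lower from compound 1 to compound 2 (beyond the scatter). Compound 3 `CCCCCCOC(=N)NC(=N)Nc1ccc(Cl)cc1` has a different core; the difference between the two cores is not broken down here. In this assay compound 3 gives 4.32, the lowest of the three measured numbers, standing well apart from both compound 2 and compound 1.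

Compound 4 `CCOC(=N)NC(=N)Nc1ccc(Cl)cc1` has not yet been measured. It arises from compound 3 by the change (hydrogen in place of butyl on a saturated chain carbon, two bonds along the chain from an oxygen on an unsaturated carbon). For the measured compounds named here, this is the same kind of change as the one from compound 1 to compound 2, though not the same: there the place was eight bonds along the chain from an amine nitrogen, here it is two bonds along the chain from an oxygen on an unsaturated carbon. The step in this assay from compound 3 to compound 4 is expected to be a number 2.00 log units lower from compound 3 to compound 4 (beyond the scatter), a size that rests on the earlier step of a number 2.00 log units lower from compound 1 to compound 2 (beyond the scatter). That earlier step is seen in the two values themselves: in this assay compound 1 gives 7.13, while compound 2 gives 5.13, and together they show how much the loss of a butyl cost there. In this assay compound 4 is therefore estimated at 2.32, most likely between 1.6 and 3.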

Compound 4, partition coefficient: 2.32
For compound 4 middle estimate and measured number coincide at the digits printed, within the range that was stated.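

In this assay, replacing butyl with hydrogen gave a number 2.00 log units lower from compound 3 to compound 4 (beyond the scatter) and so matched at the printed digits the earlier a number 2.00 log units lower from compound 1 to compound 2 (beyond the scatter) even though the core differs and the place has moved, from eight bonds along the chain from an amine nitrogen to two bonds along the chain from an oxygen on an unsaturated carbon. For the compounds shown here, this shows that the change kept its size across these two cores on this one read-out, but with only two pairs it establishes no general rule for other cores, other starting chains or other places on the chain. No measurement at hand bears on why the two steps agree, so the match remains an observation and not an explanation.

The compounds shown leave open whether the same step would appear with an amine or a carboxylic acid at the end of the chain, or with a cyclohexyl group in place of the straight chain. They also leave open whether the change would keep its size on a core with a sulfur in place of the oxygen or the amine nitrogen that carries the chain.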